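The source may hold more compounds than are shown below. What is called first, only, known or untested is meant among the compounds shown, and "the series" means these compounds.

Working notes on the series. Compound 1 `Cn1ccc2c(Oc3ccc(NC(=O)c4cc5cccnc5n(-c5ccc(Br)cc5F)c4=O)cc3)ccnc21` differs from compound 2 only in the halogen pattern on one aromatic ring; in a functional assay on NCI-H460 cells (Homo sapiens) for antiproliferative activity, read by MTT assay, with a stated time of 72 h (a higher number here means a weaker inhibitor, a lower number a stronger inhibitor), compound 1 gives "not determined" (no result reported), so no number is in hand for it. Compound 2 `Cn1ccc2c(Oc3ccc(NC(=O)c4cc5cccnc5n(-c5ccc(C(F)(F)F)cc5Cl)c4=O)cc3)ccnc21` carries a trifluoromethyl and a chloro instead, and in this assay compound 2 gives 6950 nM. Among the compounds with values here, that is the only number in hand: compound 2 stands alone, with no second value to rank it against, and compound 1 adds no number beside it.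

Compound 3 `Cn1ccc2c(Oc3ccc(NC(=O)c4cc5cccnc5n(-c5ccc(C(F)(F)F)cc5Cl)c4=O)cc3F)ccnc21` is the next variation on compound 2: fluoro in place of hydrogen on an aromatic carbon. Within the data shown here, no step between measured compounds exists to calibrate a change of this kind, so the series itself offers no precedent. The expectation for compound 3 therefore rests on compound 2 alone. A single fluoro for hydrogen is expected to move the value only modestly, close to or just beyond the scatter, with no firm direction; the estimated step is a 1.4-fold lower number from compound 2 to compound 3 (0.14 log units; within the scatter). Compound 3 is estimated at 5000 nM in this assay, with a range from 2000 nM to 15000 nM.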

Compound 3, half-maximal inhibitory concentration: 6010 nM
Beside the measured number, compound 3's estimate is 1.2-fold (0.08 log units) below it; low and high end bracket the measured number.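

In this assay, the series now has its first step for this kind of change: fluoro in place of hydrogen on an aromatic carbon of a six-membered aromatic ring of carbon only, ortho to a large group and meta to a large group, gives a 1.2-fold lower number from compound 2 to compound 3 (0.06 log units; within the scatter). At this position, then, the single fluoro leaves the antiproliferative read-out indistinguishable from that of the parent, so the hydrogen there can be exchanged for fluoro without a change that stands out from the scatter. No measurement that would explain this result is in hand.

The compounds shown leave open whether a larger group at the same position, such as methoxy, an amine or a carboxylic acid, would give a step beyond the scatter. They also leave open whether fluoro for hydrogen gives a step of like size when the trifluoromethyl and chloro pattern of compound 2 is replaced by another halogen pattern.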